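Exchanging one phenyl group on a shared core

The source may report more compounds than this note shows. Statements on the series, on what has been measured and on what is new or still open speak of the compounds shown alone.

compound 1 `N#Cc1ccc(/C=C/C(=O)Nc2cc3c(Nc4ccc(F)c(Cl)c4)ncnc3cc2O[C@H]2CCOC2)cc1`: "not determined" (no result reported)
compound 2 `COc1ccc(OC)c(/C=C/C(=O)Nc2cc3c(Nc4ccc(F)c(Cl)c4)ncnc3cc2O[C@H]2CCOC2)c1`: 26800 nM

In a functional assay on HeLa cells (Homo sapiens) for cytotoxicity, read by MTT assay, with a stated time of 72 h (a lower number here means a stronger inhibitor, a higher number a weaker inhibitor), compound 2 gives 26800 nM. Among the compounds with values here, this is the only number so far, so it cannot be ranked against anything, and compound 1 has no result. Compound 3 `O=C(/C=C/c1cc(Br)c(O)c(Br)c1)Nc1cc2c(Nc3ccc(F)c(Cl)c3)ncnc2cc1O[C@H]1CCOC1` keeps the shared core but changes one group: 3,5-dibromo-4-hydroxyphenyl in place of 2,5-dimethoxyphenyl on a double-bonded chain carbon bound to a double-bonded chain carbon. The new 3,5-dibromo-4-hydroxyphenyl group sits on a double-bonded chain carbon bound to a double-bonded chain carbon. Within the data shown here, no measured step shows how much such a change matters, so any forecast is uncertain. The estimated change is a 2.7-fold lower number from compound 2 to compound 3 (0.43 log units; beyond the scatter), toward a stronger inhibitor. Compound 3 is expected at 10000 nM, with an estimated range of 2500 nM to 40000 nM.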

Compound 3, half-maximal inhibitory concentration: 27700 nM
Compound 3: middle estimate off by 2.8-fold (0.44 log units), on the low side; measured number inside the range.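

Exchanging 2,5-dimethoxyphenyl for 3,5-dibromo-4-hydroxyphenyl gives a 1.0-fold higher number from compound 2 to compound 3 (0.01 log units; within the scatter) in this assay, so the two compounds cannot be told apart. Within the data shown here, this is the first readable step at this place, and it shows that two differently substituted phenyl groups, one with two bromines and a hydrogen-bond donor, can give matching results here. Nothing available explains this match. Going by these compounds, both measured groups are substituted phenyl rings, so it remains open whether any group on this chain carbon shifts the number. A dimethylamino group or a carboxylic acid in place of the ring could show that.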